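The source may report more compounds than this note shows. Statements on the series, on what has been measured and on what is new or still open speak of the compounds shown alone.

In an ADME assay on L929 cells (Mus musculus) for cytotoxicity, read by resazurin assay, with a stated time of 48 h (on this read-out higher numbers stand for lower toxicity in this test and lower numbers for higher toxicity in this test), three compounds sharing one core have been measured: compound 1 `O=C(O)CCn1c2ccc([N+](=O)[O-])cc2c(=O)n1Cc1ccccc1`, compound 2 `O=c1c2cc([N+](=O)[O-])ccc2n(CCCO)n1Cc1ccccc1` and compound 3 `COCCn1c2ccc([N+](=O)[O-])cc2c(=O)n1Cc1ccccc1`. Compound 1 gives > 256000 nM, which is a limit. Compound 2 gives > 256000 nM, also a limit. Compound 3 gives > 256000 nM, again a limit and not a number. Compound 3 therefore has no exact place in the series and stands with the others at the limit of > 256000 nM in this assay, at which 3 of the 3 values shown sit.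

Compound 4 `CC(=O)OCCn1c2ccc([N+](=O)[O-])cc2c(=O)n1Cc1ccccc1` differs from compound 3 at one place: acetyl in place of methyl on an oxygen on a saturated carbon. This puts acetyl in place of methyl on an oxygen on a saturated carbon, turning 2-methoxyethyl into 2-acetoxyethyl.

The nearest evidence is a step that the two limits leave unreadable from compound 1 to compound 3, together with a step that the two limits leave unreadable from compound 2 to compound 3 and a step that the two limits leave unreadable from compound 1 to compound 2. None of these has a readable size, so they set no scale for the change and do not exclude a real drop. In this assay, no step beyond the scatter is expected, and the estimated change is a number no higher from compound 3 to compound 4 (the limit leaves the size open). The estimate for compound 4 is 256000 nM. The expected range for compound 4 runs from 100000 nM to 400000 nM.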

Compound 4, concentration lethal to 50% of the cells: > 256000 nM
Compound 4 was reported as a limit; the forecaster's own chance of this, stated with the estimate: 75%; the middle value sits exactly at the limit.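

In this assay, among these compounds, compound 4 gives > 256000 nM, a limit and not a number, so no step from compound 1, compound 2 or compound 3 to compound 4 can be read. The compounds shown leave open whether any change on this chain gives a measurable lethal concentration: the limit of > 256000 nM in this assay, at which 4 of the 4 values shown sit.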